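The source may hold more compounds than are shown below. What is called first, only, known or untested is meant among the compounds shown, and "the series" means these compounds.

Measured in a functional assay on CHO cells for antagonist activity at metabotropic glutamate receptor 7 (Rattus norvegicus), read by FLIPR and calcium flux; on this read-out lower numbers stand for stronger inhibition and higher numbers for weaker inhibition:
compound 1 `COc1ccc(-c2cc3onc(-c4ccccc4)c3c(=O)n2C)cc1` gives 22 nM
compound 2 `Cn1c(-c2ccc(F)cc2)cc2onc(-c3ccccc3)c2c1=O` gives 72 nM
compound 3 `CN(C)c1ccc(-c2cc3onc(-c4ccccc4)c3c(=O)n2C)cc1` gives 140 nM

Compound 3 carries the highest number of the three: its gap from compound 1 is a 6.4-fold higher number from compound 1 to compound 3 (0.80 log units; beyond the scatter), its gap from compound 2 only a 1.9-fold higher number from compound 2 to compound 3 (0.29 log units; within the scatter). Compound 4 `CC(C)Oc1ccc(-c2cc3onc(-c4ccccc4)c3c(=O)n2C)cc1` is not yet measured; it differs from compound 3 by isopropoxy in place of dimethylamino on an aromatic carbon. Going by the values given here, the one measured step that bears on this change is the one that introduced the dimethylamino in place of methoxy, a 6.4-fold higher number from compound 1 to compound 3 (0.80 log units; beyond the scatter). Isopropoxy is an alkoxy group like methoxy but not the same one, and no step between two alkoxy groups is measured here. A partial return toward the number of compound 1 is therefore expected for compound 4 in this assay, a step of about a 2.8-fold lower number from compound 3 to compound 4 (0.45 log units; beyond the scatter). Compound 4 is expected at 50 nM, within 15 nM to 160 nM.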

Compound 4, half-maximal inhibitory concentration: > 10000 nM
Compound 4: no number, only a limit (the forecaster's own chance of this, stated with the estimate: 3%); middle value at least 200-fold (2.30 log units) from the limit.
By their numbers in this assay, from the lowest: compound 1; then compounds 2 and 3 (each within the scatter of the next). At a limit, above all of these: compound 4.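

In this assay compound 4 gives a limit and not a number: the limit of > 10000 nM in this assay, at which 1 of the 4 values shown sits.
On this aromatic carbon, para to a large group, methoxy, fluoro and dimethylamino all leave measurable inhibition, whereas isopropoxy does not (an at least 71-fold higher number from compound 3 to compound 4 (1.85 log units; beyond the scatter); an at least 130-fold higher number from compound 2 to compound 4 (2.14 log units; beyond the scatter)).
The sharpest contrast lies within the alkoxy pair, where isopropyl in place of methyl on the oxygen gives an at least 450-fold higher number from compound 1 to compound 4 (2.65 log units; beyond the scatter), so an oxygen at this place does not by itself keep the activity.

Ethoxy remains open as the nearest alkoxy group to test. A straight propoxy chain would show whether the loss follows branching or chain length.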